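The source may report more compounds than this note shows. Statements on the series, on what has been measured and on what is new or still open speak of the compounds shown alone.

Measured in a functional assay on SK-MEL-28 cells (Homo sapiens) for inhibition, with a stated time of 48 h; on this read-out higher numbers stand for weaker inhibition of growth and lower numbers for stronger inhibition of growth:
- compound 1 `COc1ccccc1/C=C/C(=O)c1c(O)cc2occc2c1OC`: > 100000 nM (a limit of the assay)
- compound 2 `COc1c(C(=O)/C=C/c2ccc(Cl)cc2)c(O)c(Br)c2occc12`: 9860 nM
- compound 3 `C=CCc1c(O)c(C(=O)/C=C/c2ccccc2)c(OC)c2ccoc12`: 2490 nM

Compound 3 has the lower of the two actual numbers in this assay, and its gap to compound 2 lies beyond the scatter. Compound 1 reached only the limit of the assay, so it gives no number to rank.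

Compound 4 `C=CCc1c(O)c(C(=O)/C=C/c2ccc(Cl)cc2)c(OC)c2ccoc12` is compound 3 with one change, chloro in place of hydrogen on an aromatic carbon, para to a large group, which turns phenyl into 4-chlorophenyl (chloro in place of hydrogen on an aromatic carbon). For the measured compounds named here, no measured pair isolates this change. Going by the values given here, compound 2 already carries the 4-chlorophenyl group and gives 9860 nM, but it differs from compound 3 in other places too, so it sets no size for the step. In this assay, the expected result is no shift beyond the scatter, with a slight lean towards stronger inhibition of growth, as the estimated step of a 1.1-fold lower number from compound 3 to compound 4 (0.05 log units; within the scatter). For compound 4 the expected value is 2200 nM, with an estimated range from 800 nM to 6500 nM.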

Compound 4, concentration for 50% growth inhibition: 2320 nM
Beside the measured number, compound 4's estimate is 1.1-fold (0.02 log units) below it; measured number inside the range.
By their numbers in this assay, from the lowest: compounds 4 and 3 (each within the scatter of the next); then compound 2. At a limit, above all of these: compound 1.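

In this assay, the swap of phenyl for 4-chlorophenyl now has a clean pair, and the step reads a 1.1-fold lower number from compound 3 to compound 4 (0.03 log units; within the scatter), so chloro in place of hydrogen on this aromatic carbon, para to a large group, makes no difference that stands clear of the scatter. Compound 2 had carried the same 4-chlorophenyl group, but only now can it be paired with a compound that differs from it in one place. With allyl in place of bromo on an aromatic carbon, that pair gives a 4.3-fold lower number from compound 2 to compound 4 (0.63 log units; beyond the scatter), a step beyond the scatter.

As far as these compounds go, whether a methoxy group or an amine para to the large group would stay as close to compound 3 remains open, as does whether a longer chain in place of allyl would hold the value of compound 4. Nothing measured here gives a cause for either step.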